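Ring-nitrogen acetylation in a weakly active pyrazole-free series

The source may hold more compounds than are shown below. What is called first, only, known or untested is meant among the compounds shown, and "the series" means these compounds.

Measured compounds:
Compound 1 `Cc1[nH]nc(N)c1-c1ccc(Cl)c(Cl)c1` gives > 100000 nM in an assay on Sf9 cells for inhibition of inhibitor of nuclear factor kappa-B kinase subunit epsilon (Homo sapiens), read by ADP-Glo, with a stated time of 60 min (a higher number here means a weaker inhibitor, a lower number a stronger inhibitor), a limit of the assay.
Compound 2 `Cc1[nH]nc(N)c1-c1cccc(Cl)c1` gives 93400 nM in this assay.
Compound 3 `Cc1[nH]nc(N)c1-c1cccc(Br)c1` gives > 100000 nM in this assay, a limit of the assay.

Compound 1 stands at the limit of > 100000 nM in this assay, at which 2 of the 3 values shown sit. The two measured steps, an at least 1.0-fold lower number from compound 1 to compound 2 (0.02 log units; that floor lies within the scatter) and an at least 1.0-fold higher number from compound 2 to compound 3 (0.02 log units; that floor lies within the scatter), both change a substituent on an aromatic carbon, and neither resolves a shift in this assay. Compound 4 `CC(=O)n1nc(N)c(-c2ccc(Cl)c(Cl)c2)c1C` differs from compound 1 by acetyl in place of hydrogen on an aromatic nitrogen. Among the compounds with values here, no measured step touches the aromatic nitrogen, so nothing here bears directly on this change, and the series as a whole sits at or near the upper boundary of this assay. A step of about a number no higher from compound 1 to compound 4 (the limit leaves the size open) is expected, that is, none beyond the scatter. Compound 4 is estimated at 100000 nM, within 30000 nM to 300000 nM, with a further limit reading likely.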

Compound 4, half-maximal inhibitory concentration: > 100000 nM
Compound 4: no number, only a limit; the forecaster's own chance of this, stated with the estimate: 70%; the middle value sits exactly at the limit.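

Compound 1 and compound 4 both give limits of the assay rather than numbers, so no step between them can be read: the limit of > 100000 nM in this assay, at which 3 of the 4 values shown sit.

On these data alone, whether acetyl in place of hydrogen on the aromatic nitrogen shifts inhibition at all remains open.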